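Amino for Nitro: Expecting Another Limit

The source may hold more compounds than are shown below. What is called first, only, known or untested is meant among the compounds shown, and "the series" means these compounds.

Of the compounds shown here, two that share one core have been tested in an ADME assay on HUVEC cells (Homo sapiens) for antiproliferative activity, read by MTT assay, with a stated time of 48 h; on this read-out lower numbers stand for stronger inhibition and higher numbers for weaker inhibition. Compound 1 `N#CC1=C(N)Oc2c(c3nc4ccccc4nc3c3ccccc23)C12C(=O)N(Cc1cnnn1-c1ccc(F)cc1)c1ccccc12` carries a fluoro on an aromatic carbon, and compound 2 `N#CC1=C(N)Oc2c(c3nc4ccccc4nc3c3ccccc23)C12C(=O)N(Cc1cnnn1-c1ccc([N+](=O)[O-])cc1)c1ccccc12` carries a nitro in place of that fluoro. In this assay compound 1 gives > 50000 nM, which is a limit of the assay rather than a number. Compound 2 gives > 50000 nM, again a limit and not a number. The step that the two limits leave unreadable from compound 1 to compound 2 is therefore unreadable in size, and compound 2 stands at the limit of > 50000 nM in this assay, at which 2 of the 2 values shown sit, alongside compound 1.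

Compound 3 `N#CC1=C(N)Oc2c(c3nc4ccccc4nc3c3ccccc23)C12C(=O)N(Cc1cnnn1-c1ccc(N)cc1)c1ccccc12` differs from compound 2 by amino in place of nitro on an aromatic carbon. For the measured compounds named here, the only measured step, a step that the two limits leave unreadable from compound 1 to compound 2, gives no readable size, so no measured change offers a direction for this one. With both known compounds sitting at the limit, the most reasonable expectation is that compound 3 also sits there. Compound 3 is expected to give about 50000 nM. For compound 3 the expected range runs from 20000 nM to 100000 nM. The step of a number no higher from compound 2 to compound 3 (the limit leaves the size open) is thus expected to stay within the scatter.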

Compound 3, half-maximal inhibitory concentration: > 50000 nM
Compound 3: only a limit was reported; the forecaster's own chance of this, stated with the estimate: 75%; the middle value lies on the limit itself.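

In this assay compound 3 gives > 50000 nM, a limit and not a number. No step among compound 1, compound 2 and compound 3 can be read, as all three stand at the same limit: the limit of > 50000 nM in this assay, at which 3 of the 3 values shown sit.

The compounds shown leave open whether fluoro, nitro or amino at this place makes any difference in this assay.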